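Removing one chloro from a dichloropurine: an expected loss

This account rests on a few compounds, and the source may have more. Where it says the series, first, only, none or still open, it means among the compounds named here.

Measured so far:
compound 1 `ClCc1ccc(Cn2cnc3nc(Cl)nc(Cl)c32)cc1` — 6300 nM
compound 2 `ClCc1ccccc1Cn1cnc2ncnc(Cl)c21` — 45700 nM
compound 3 `ClCc1ccccc1Cn1cnc2nc(Cl)nc(Cl)c21` — 6020 nM

In a functional assay on EKVX cells (Homo sapiens) for cytotoxicity, read by sulforhodamine B assay, with a stated time of 48 h (a lower number here means that less compound is tolerated, a higher number that more compound is tolerated), compound 3 gives 6020 nM, and compound 2, which carries hydrogen in place of chloro on an aromatic carbon, gives 45700 nM, a step of a 7.6-fold higher number from compound 3 to compound 2 (0.88 log units; beyond the scatter). Compound 1 and compound 3 are built from the same atoms joined differently; the difference between the two cores is not broken down here. Compound 4 `ClCc1ccc(Cn2cnc3ncnc(Cl)c32)cc1` has not yet been tested; it carries hydrogen in place of chloro on an aromatic carbon, the same change seen from compound 3 to compound 2. Because that earlier step was a 7.6-fold higher number from compound 3 to compound 2 (0.88 log units; beyond the scatter), a step of similar size is expected here, namely a 7.1-fold higher number from compound 1 to compound 4 (0.85 log units; beyond the scatter), resting on that single precedent. For compound 4 in this assay the expected value is therefore 45000 nM, roughly between 15000 nM and 120000 nM.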

Compound 4, concentration lethal to 50% of the cells: 8700 nM
The estimate for compound 4 lay 5.2-fold (0.71 log units) above the measured number, and the stated range ends above it.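

In this assay, putting hydrogen in place of chloro on the core of compound 1 gives a 1.4-fold higher number from compound 1 to compound 4 (0.14 log units; within the scatter), so on this core the swap makes no difference that can be told from the scatter. The same swap therefore does not carry over at the same size from one core to the other: the same change on two cores in this assay, a 7.6-fold higher number (0.88 log units; beyond the scatter) from compound 3 to compound 2 and a 1.4-fold higher number (0.14 log units; within the scatter) from compound 1 to compound 4, 5.5-fold (0.74 log units) apart, beyond the scatter of two such steps. Within the data shown here, with only one pair on each core, this shows that the size of the step depends on the core in these four compounds, but not which feature of the cores is responsible or what a third core would do.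

The compounds shown leave open how an amine or a methoxy group in place of that chloro would behave on either core.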